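The source may hold more compounds than are shown below. What is called first, only, known or untested is meant among the compounds shown, and "the series" means these compounds.

Measured so far:
- compound 1, `O=C(Nc1ccc(Cl)cc1Cl)c1ccc(S(=O)(=O)Nc2ccccc2)cc1`: > 100000 nM
- compound 2, `Cc1cc(Cl)ccc1C(=O)Nc1ccc(S(=O)(=O)Nc2ccccc2)cc1`: 912 nM
- compound 3, `Cc1ccc(NS(=O)(=O)c2ccc(NC(=O)c3ccc(Cl)cc3Cl)cc2)cc1`: > 100000 nM

Notes on the series. Going by the values given here, in a functional assay on HEK293 cells for agonist activity at probable G-protein coupled receptor 27 (Homo sapiens), read by a luciferase reporter and beta-arrestin recruitment, with a stated time of 10 min (a higher number here means that more compound is needed for the effect, a lower number that less compound is needed), compound 2 gives 912 nM, the only number among the three values shown. Compound 1 gives only a limit of the assay, > 100000 nM. Compound 3 likewise gives only a limit, > 100000 nM. Among the compounds with values here, two of the three values thus sit at the limit of > 100000 nM in this assay, at which 2 of the 3 values shown sit, and compound 2 stands alone as the one compound with a measured concentration.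

Within the data shown here, no two measured compounds differ in a single place, so no measured step is available to calibrate the change now considered. Compound 4, `COc1cc(Br)ccc1C(=O)Nc1ccc(S(=O)(=O)Nc2ccccc2)cc1`, is yet to be measured in this assay. It differs from compound 2 in one place: 4-bromo-2-methoxyphenyl in place of 4-chloro-2-methylphenyl on a carbonyl carbon.

Among the measured compounds shown here, with no measured step to lean on, the expectation rests on compound 2 alone. The change is expected to give a 2.7-fold higher number from compound 2 to compound 4 (0.44 log units; beyond the scatter), a modest loss beyond the scatter and well short of the limit. Compound 4 is therefore estimated at 2500 nM, with a range from 500 nM to 20000 nM, and a real chance that only a limit is returned.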

Compound 4, half-maximal effective concentration: 1020 nM
For compound 4 the middle estimate is 2.5-fold (0.39 log units) above the measured one; the measured number falls inside the stated range.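

In this assay, going by these compounds alone, the one step measured is a 1.1-fold higher number from compound 2 to compound 4 (0.05 log units; within the scatter), with 4-bromo-2-methoxyphenyl in place of 4-chloro-2-methylphenyl on a carbonyl carbon. At this place, then, bromine for chlorine and methoxy for methyl, taken together, leave the two numbers within the scatter, even though the entering group carries a hydrogen-bond acceptor and the leaving group carries none. Compound 4 also returns a measured number, so it stays apart from the values that are only a limit of the assay: the limit of > 100000 nM in this assay, at which 2 of the 4 values shown sit.

Both parts of the group change in this one step, so the compounds shown cannot say whether each exchange is silent alone or whether two opposing contributions cancel. Also open, on these data alone, is how far this tolerance extends, for instance to a carboxylic acid or an amine in place of the methoxy, or to a longer chain such as butoxy, and whether it would hold on a core other than that of compound 2.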